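The compounds below may be only part of what the source reports. "The series", "measured", "known", "first", "only" and "open" are said of these compounds alone.

Measured compounds: compound 1 `Oc1ccccc1CNc1ccc(-c2ccccc2)cc1` at 1820 nM; compound 2 `Cc1ccc(-c2ccc(NCc3ccccc3O)cc2)cc1` at 3790 nM.

In a functional assay on Jurkat cells (Homo sapiens) for activation, with a stated time of 24 h (a higher number here means that more compound is needed for the effect, a lower number that less compound is needed), compound 1 gives 1820 nM and compound 2 gives 3790 nM. Compound 2 stands highest of the two numbers shown, with compound 1 its nearest neighbour at a lower number; the step between them is a 2.1-fold higher number from compound 1 to compound 2 (0.32 log units; beyond the scatter). Compound 3 `Oc1cccc(-c2ccc(NCc3ccccc3O)cc2)c1` differs from compound 2 by 3-hydroxyphenyl in place of 4-methylphenyl on an aromatic carbon. Going by the values given here, only one measured step bears on this change, and only in part: a 2.1-fold higher number from compound 1 to compound 2 (0.32 log units; beyond the scatter) shows the methyl's entry raising the number modestly, so its departure in compound 3 should give that back, while the hydroxyl's entry has no measured counterpart in this pair. Compound 3 is therefore expected near the number of compound 1, at an estimated 2000 nM, between 700 nM and 6000 nM. That estimate means an expected step of a 1.9-fold lower number from compound 2 to compound 3 (0.28 log units; within the scatter) in this assay.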

Compound 3, half-maximal effective concentration: "not active" (no number reported)
For compound 3 the study gives words and no number, and the estimate cannot be compared.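

Going by these compounds alone, compound 3 is reported as "not active", in words without a number, so no step from compound 2 to compound 3 can be read. Nothing shown here explains that result. The compounds shown leave open what the 3-hydroxyphenyl group alone does to the activity of the shared core.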